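This account rests on a few compounds, and the source may have more. Where it says the series, first, only, none or still open, it means among the compounds named here.

The measured compounds:
compound 1, `Cn1c(=O)oc2cc(S(=O)(=O)Nc3ccccc3Sc3ccccc3)ccc21`: 3.91
compound 2, `O=C(Nc1ccccc1)Nc1ccc(Oc2cccc(C(F)(F)F)c2)nc1`: 5.04
compound 3, `C[C@@H](CS(=O)(=O)Nc1ccc2c(c1)oc(=O)n2C)c1ccccc1`: 3.06

All three numbers come from a physicochemical assay for lipophilicity; on this read-out higher numbers stand for higher lipophilicity and lower numbers for lower lipophilicity. In this assay compound 1 gives 3.91, the second highest of the three. Its nearest neighbour is compound 3, which gives 3.06, a number lower by more than the usual scatter. Furthest from it is compound 2, which gives 5.04, a number higher by more than the scatter.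

Compound 4, `Cn1c(=O)oc2cc(S(=O)(=O)Nc3ccccc3Oc3ccccc3Cl)ccc21`, has not yet been measured in this assay. Set beside compound 1 it shows a single change: 2-chlorophenoxy in place of phenylsulfanyl on an aromatic carbon. Among the compounds with values here, no pair of measured compounds isolates this change, so the expectation for compound 4 rests only on the value of compound 1 and on the change itself. Compound 4 is expected to give about 4.2, within a range from 3.7 to 4.7. This corresponds to an expected step of a number 0.29 log units higher from compound 1 to compound 4 (within the scatter), a small rise that may well lie within the scatter.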

Compound 4, partition coefficient: 4.32
Beside the measured number, compound 4's estimate is 0.12 log units below it; measured number inside the range.
By their numbers in this assay, from the lowest: compound 3; then compound 1; then compound 4; then compound 2.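

Within the data shown here, compound 1 and compound 4 form the first pair here that differs in one place. On an aromatic carbon ortho to a large group, 2-chlorophenoxy in place of phenylsulfanyl gives, in this assay, a number 0.41 log units higher from compound 1 to compound 4 (beyond the scatter), with the core of compound 1 unchanged. The step is modest, yet it shows that this read-out separates the two groups at this position, and no measurement at hand explains the step.

The change replaces sulfur with oxygen and adds chlorine at once, and the compounds shown do not separate these two parts, which phenoxy or 2-chlorophenylsulfanyl at this place could begin to do. Also open, as far as these compounds go, is how the read-out would respond to an amine or a carboxylic acid on this aromatic carbon.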